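Trifluoromethyl for Fluoro on the Aryl Amine

The compounds below may be only part of what the source reports. "The series", "measured", "known", "first", "only" and "open" are said of these compounds alone.

Compound 1, `C=CC(=O)Nc1cccc(NC(=O)CSc2nc(Nc3cccc(C)c3)c3ccccc3n2)c1`: 16800 nM
Compound 2, `C=CC(=O)Nc1cccc(NC(=O)CSc2nc(Nc3cccc(OC)c3)c3ccccc3n2)c1`: 12900 nM
Compound 3, `C=CC(=O)Nc1cccc(NC(=O)CSc2nc(Nc3ccc(F)cc3)c3ccccc3n2)c1`: 9490 nM

These numbers come from a functional assay on MDA-MB-231 cells (Homo sapiens) for inhibition, read by MTT assay, with a stated time of 72 h; on this read-out lower numbers stand for stronger inhibition and higher numbers for weaker inhibition. Compound 3 gives the lowest number of the three, yet its steps to the other two are small: a 1.8-fold lower number from compound 1 to compound 3 (0.25 log units; within the scatter) and a 1.4-fold lower number from compound 2 to compound 3 (0.13 log units; within the scatter). The step of a 1.3-fold lower number from compound 1 to compound 2 (0.11 log units; within the scatter) is small as well, so the three compounds cannot be told apart on these numbers.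

Compound 4, `C=CC(=O)Nc1cccc(NC(=O)CSc2nc(Nc3ccc(C(F)(F)F)cc3)c3ccccc3n2)c1`, has not been measured. It differs from compound 3 in one place: trifluoromethyl in place of fluoro on an aromatic carbon. Among the compounds with values here, no measured step changes this group in the same way; the nearest comparisons are the exchanges of the whole aryl group on the nitrogen, a 1.8-fold lower number from compound 1 to compound 3 (0.25 log units; within the scatter) and a 1.4-fold lower number from compound 2 to compound 3 (0.13 log units; within the scatter), both within the scatter. Every change of this aryl group seen so far left the number within the scatter, and no step beyond the scatter is expected for compound 4 in this assay either, in neither direction. Compound 4 is estimated at 10000 nM, with a range from 4000 nM to 25000 nM. The expected step is a 1.1-fold higher number from compound 3 to compound 4 (0.02 log units; within the scatter).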

Compound 4, half-maximal inhibitory concentration: 11500 nM
The estimate for compound 4 lay 1.2-fold (0.06 log units) below the measured number, and the stated range covers the measured number.
By their numbers in this assay, from the lowest: compounds 3, 4, 2 and 1 (each within the scatter of the next).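

Within the data shown here, compound 4 supplies the first step that changes only the substituent on this aromatic carbon, para to a large group, while the rest of the aryl amine stays the same. In this assay, among these compounds, trifluoromethyl in place of fluoro stays within the scatter (a 1.2-fold higher number from compound 3 to compound 4 (0.08 log units; within the scatter)), so this position takes a group of more heavy atoms with no step that can be read as a change. Compound 4 also stays within the scatter of the two compounds with a different aryl group (a 1.1-fold lower number from compound 2 to compound 4 (0.05 log units; within the scatter); a 1.5-fold lower number from compound 1 to compound 4 (0.16 log units; within the scatter)), and nothing at hand accounts for this flat result.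

As far as these compounds go, whether an amine or a carboxylic acid on this aromatic carbon would carry the number beyond the scatter remains open. The same holds for a longer chain at this position.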